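From Cyano to Methoxy on a Shared Core

The source may report more compounds than this note shows. Statements on the series, on what has been measured and on what is new or still open speak of the compounds shown alone.

Measured in a functional assay on SF-268 cells (Homo sapiens) for inhibition, with a stated time of 48 h; a higher number here means a weaker inhibitor of growth, a lower number a stronger inhibitor of growth:
- compound 1 `N#Cc1ccc(-n2ncc3c(N)ncnc32)cc1`: "not determined" (no result reported)
- compound 2 `CC(=O)OC[C@H]1O[C@@H](Nc2ncnc3c2cnn3-c2ccc(C(=O)O)cc2)[C@H](OC(C)=O)[C@@H](OC(C)=O)[C@@H]1OC(C)=O`: > 150000 nM

In this assay compound 1 has no numerical result, its entry reading "not determined" (no result reported). Compound 2 gives only a limit, > 150000 nM. Compound 3 `COc1ccc(-n2ncc3c(N)ncnc32)cc1` has yet to be measured. Its structure places methoxy in place of cyano on an aromatic carbon. For the measured compounds named here, no measured step shows what such a change does, and no number anchors its starting point. A moderate step is therefore expected, with no direction favoured. Compound 3 is estimated at 40000 nM, with an expected range of 8000 nM to 150000 nM.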

Compound 3, concentration for 50% growth inhibition: > 150000 nM
Compound 3 ended at the assay's limit; the forecaster's own chance of this, stated with the estimate: 35%; middle value at least 3.7-fold (0.57 log units) away from the limit.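

No step can be read between compound 1 and compound 3: compound 1 has no numerical result, and compound 3 gives only a limit. The compounds shown leave open what methoxy in place of cyano does to growth inhibition, and the values that exist stop at one point: the limit of > 150000 nM in this assay, at which 2 of the 3 values shown sit.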